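Ester Arm Replaced by Benzyl: What to Expect

The source may hold more compounds than are shown below. What is called first, only, known or untested is meant among the compounds shown, and "the series" means these compounds.

In a functional assay on B16 cells (Mus musculus) for cytotoxicity, read by MTT assay, with a stated time of 48 h (a higher number here means a weaker inhibitor, a lower number a stronger inhibitor), compound 1 `COc1cccc(Cn2cc(-c3ccc([N+](=O)[O-])cc3)nn2)c1` gives 19100 nM. Compound 2 `CCOC(=O)Cn1cc(-c2ccc([N+](=O)[O-])cc2)nn1` reaches only a limit of the assay, > 100000 nM, in this assay. Its place is marked by the limit of > 100000 nM in this assay, at which 1 of the 2 values shown sits. Compound 3 `O=[N+]([O-])c1ccc(-c2cn(Cc3ccccc3)nn2)cc1` is not yet measured and differs from compound 2 by phenyl in place of ethoxycarbonyl on a saturated chain carbon bound to an aromatic nitrogen. Since compound 1, which also carries a benzyl group, sits at 19100 nM, a move downward beyond the usual scatter is expected in this assay. The expected step is an at least 4.0-fold lower number from compound 2 to compound 3 (0.60 log units; beyond the scatter). Compound 3 is thus estimated at 25000 nM, within 8000 nM to 100000 nM.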

Compound 3, half-maximal inhibitory concentration: 5120 nM
The estimate for compound 3 lay 4.9-fold (0.69 log units) above the measured number; measured number outside the range, below it.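

Compound 2 stands at a limit of the assay, so its step gives a bound and not a size: the limit of > 100000 nM in this assay, at which 1 of the 3 values shown sits. In this assay, phenyl in place of ethoxycarbonyl on a saturated chain carbon bound to an aromatic nitrogen gives an at least 19-fold lower number from compound 2 to compound 3 (1.29 log units; beyond the scatter). Hydrogen in place of methoxy on an aromatic carbon gives a 3.7-fold lower number from compound 1 to compound 3 (0.57 log units; beyond the scatter), so the benzyl ring itself also counts, and compound 3 is the strongest of the three. On these data alone, whether an amine, a carboxylic acid or a longer chain on that saturated chain carbon would hold this level stays open.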